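From hydroxy to methoxy on compound 1

A few compounds are considered here, and "the series" means these few. Any claim that something is new, unique, unknown or untested is made for them only; others in the source may bear on it.

Values in a functional assay on BCG823 cells (Homo sapiens) for cytotoxicity, read by MTT assay (on this read-out lower numbers stand for stronger inhibition and higher numbers for weaker inhibition), are these:
- compound 1 `CC1(C)C2CCC1(C)C(OC(=O)/C=C/c1ccc(O)c(O)c1[N+](=O)[O-])C2` gives 117000 nM
- compound 2 `CC1(C)C2CCC1(C)C(OC(=O)/C=C/c1ccc(O)c(O)c1)C2` gives 101000 nM
- compound 3 `COc1cc(/C=C/C(=O)OCCc2ccccc2)cc(Br)c1O` gives > 300000 nM as a limit, not a number

Among the measured compounds shown here, compound 1 and compound 2 hold the only two numbers, and these lie within the scatter of each other. Compound 4 `COc1c(O)ccc(/C=C/C(=O)OC2CC3CCC2(C)C3(C)C)c1[N+](=O)[O-]` differs from compound 1 by methyl in place of hydrogen on an oxygen on an aromatic ring, that is, hydroxy to methoxy (methyl in place of hydrogen on an oxygen on an aromatic ring). For the measured compounds named here, no measured step makes this change. Going by the values given here, the one measured step is a 1.2-fold lower number from compound 1 to compound 2 (0.06 log units; within the scatter) and replaces nitro instead, so it is only a loose guide. No step beyond the scatter is therefore expected in this assay for this change. The expected step is a 1.1-fold higher number from compound 1 to compound 4 (0.05 log units; within the scatter). Compound 4 is estimated at 130000 nM within a range of 60000 nM to 300000 nM in this measurement.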

Compound 4, half-maximal inhibitory concentration: 32100 nM
Compound 4: the middle estimate sits 4.0-fold (0.61 log units) above what was measured; measured number below the stated range.
By their numbers in this assay, from the lowest: compound 4; then compounds 2 and 1 (each within the scatter of the next). At a limit, above all of these: compound 3.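

Replacing hydroxy with methoxy on this oxygen gives a 3.6-fold lower number from compound 1 to compound 4 (0.56 log units; beyond the scatter) in this assay, and this is the first step shown that lies beyond the scatter. The number on this core can therefore move with a small change at this oxygen on the aromatic ring, whereas the earlier step that removed nitro did not move it beyond the scatter. Nothing shown here gives a reason for this step.

This remains a single pair of compounds, so no general pattern follows from it. Going by these compounds, a longer chain such as ethyl on this oxygen, or an amine in place of the hydroxy, remains open.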